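The source may hold more compounds than are shown below. What is called first, only, known or untested is meant among the compounds shown, and "the series" means these compounds.

Measured so far:
compound 1, `O=C(O)[C@H]1NC[C@H](O)[C@H](O)[C@@H]1O`, 4.5%
compound 2, `O=C(O)[C@H]1NC[C@H](O)[C@H](O)[C@H]1O`, 21%
compound 3, `O=C(O)[C@@H]1NC[C@@H](O)[C@@H](O)[C@H]1O`, 8.2%

These three compounds share every atom and bond and differ only in how their stereocentres are drawn. In an assay for inhibition of alpha-N-acetylgalactosaminidase (Gallus gallus), tested at 1000 uM (a lower number here means less inhibition, a higher number more inhibition at the concentration tested (going by the name of the read-out)), compound 3 gives 8.2%, the second highest of the three numbers: the gap to compound 1 is within the usual scatter, while compound 2 sits above it by a clear margin, as a number 12.8 percentage points lower from compound 2 to compound 3 (beyond the scatter) shows.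

Compound 4, `O=C(O)[C@H]1NC[C@@H](O)[C@@H](O)[C@@H]1O`, has not been measured yet. It differs from compound 3 as follows: the two compounds have the same atoms and bonds and differ only in configuration as drawn: 2 of 4 stereo elements differ; a stereocentre at a saturated ring carbon is drawn R in compound 3 and S in compound 4; a stereocentre at a saturated ring carbon is drawn S in compound 3 and R in compound 4

The measured steps show what inverting stereocentres can do here. Turning one centre gave a number 16.5 percentage points higher from compound 1 to compound 2 (beyond the scatter); turning all four gave a number 3.7 percentage points higher from compound 1 to compound 3 (within the scatter); turning three gave a number 12.8 percentage points lower from compound 2 to compound 3 (beyond the scatter). The direction of such a change therefore cannot be read off the count of inverted centres, and the sizes seen are modest at most. For compound 4, inverting two centres is expected to give a modest shift of uncertain direction, a number 1.8 percentage points higher from compound 3 to compound 4 (within the scatter), leading to an estimate of 10% with a range from 2% to 25%.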

Compound 4, a percentage reported as inhibition, at one concentration (the size of the read-out at that concentration, not a potency): 3.8%
Beside the measured number, compound 4's estimate is 6.2 percentage points above it; measured number inside the range.
By their numbers in this assay, from the lowest: compounds 4, 1 and 3 (each within the scatter of the next); then compound 2.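

In this assay, both pairs that differ at two centres stay within the scatter: a number 4.4 percentage points lower from compound 3 to compound 4 (within the scatter), and a number 0.7 percentage points lower from compound 1 to compound 4 (within the scatter). The three-centre change gives a much clearer gap, a number 17.2 percentage points lower from compound 2 to compound 4 (beyond the scatter), so compound 2 now stands apart from all three other stereoisomers. Compound 2 has the highest number of the set at 21%, yet this remains a modest reading and no other arrangement shown comes close to it.

Within the data shown here, whether each of the other centres would matter on its own stays open: only one step here turns a single centre. The compounds also leave open how the numbers would respond if a primary amide or a methyl ester took the place of the carboxylic acid on the shared core.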